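A few compounds are considered here, and "the series" means these few. Any claim that something is new, unique, unknown or untested is made for them only; others in the source may bear on it.

Measured in an assay on isolated protein for antagonist activity at Sigma intracellular receptor 2 (Homo sapiens), read by scintillation counting, with a stated time of 120 min, in the presence of a further agent that is not named here; on this read-out higher numbers stand for weaker inhibition and lower numbers for stronger inhibition:
compound 1 `O=C(c1nn(Cc2ccccc2)c2c1CC(NCc1ccc(F)cc1)CC2)N1CCCCC1` gives > 10000 nM, a limit of the assay.
compound 2 `O=C(c1c2c(nn1-c1ccccc1)CCC(NCc1ccc(F)cc1)C2)N1CCCCC1` gives 158 nM.
compound 3 `CCCn1nc(C(=O)N(C)C)c2c1CCC(SCc1ccc(F)cc1)C2` gives > 10000 nM, a limit of the assay.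

For the measured compounds named here, compound 2 holds the only number in this assay; the other two values stand at the limit of > 10000 nM in this assay, at which 2 of the 3 values shown sit, so no measured step of any kind is available and nothing can be said of how compound 2 compares beyond that.

Compound 4 `O=C(c1c2c(nn1-c1ccccc1)CCC(NCc1ccccc1)C2)N1CCCCC1` differs from compound 2 by hydrogen in place of fluoro on an aromatic carbon. Going by the values given here, no measured pair shows this change. The expected step of a 1.6-fold higher number from compound 2 to compound 4 (0.20 log units; within the scatter) is small, toward weaker inhibition, and may well lie within scatter. Compound 4 is estimated at 250 nM, between 80 nM and 800 nM.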

Compound 4, inhibition constant: 126 nM
Compound 4: middle estimate off by 2.0-fold (0.30 log units), on the high side; measured number inside the range.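

In this assay, going from 4-fluorobenzyl to benzyl gives a 1.3-fold lower number from compound 2 to compound 4 (0.10 log units; within the scatter). For the compounds shown here, this is the first readable step, and it shows that fluoro on this aromatic carbon, para to a large group, is not required for inhibition at this level. The other values allow no further step: the limit of > 10000 nM in this assay, at which 2 of the 4 values shown sit.

Going by these compounds, whether a larger group at the same place, such as methoxy or trifluoromethyl, would read the same remains open. So does the outcome with an amine or a carboxylic acid there.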